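The compounds below may be only part of what the source reports. "The series", "measured", "known", "first", "only" and "open" are said of these compounds alone.

Three compounds have been measured in an ADME assay on HepG2 cells (Homo sapiens) for cytotoxicity, read by MTT assay, with a stated time of 24 h (on this read-out lower numbers stand for stronger inhibition and higher numbers for weaker inhibition), and each result is a limit of the assay rather than a number:

- Compound 1 `O=C(Nc1ccc(Oc2ccccc2)cc1)C1=CO[C@@H](O[C@@H]2O[C@H](COCc3ccccc3)[C@@H](OCc3ccccc3)[C@H](OCc3ccccc3)[C@H]2OCc2ccccc2)[C@@H]2C(COCc3ccccc3)=CC[C@H]12`: > 200000 nM
- Compound 2 `CCOS(=O)(=O)/C=C/c1ccc(OCC2=CC[C@@H]3C(C(=O)Nc4ccc(Oc5ccccc5)cc4)=CO[C@@H](OC)[C@H]23)cc1`: > 200000 nM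
- Compound 3 `CCOS(=O)(=O)/C=C/c1ccc(OCC2=CC[C@@H]3C(C(=O)Nc4ccc(Oc5ccc(-c6ccccc6)cc5)cc4)=CO[C@@H](OC)[C@H]23)cc1`: > 200000 nM

Compound 3 therefore has no exact position on the scale. Its > 200000 nM is only a limit. The whole set shares this outcome, with the limit of > 200000 nM in this assay, at which 3 of the 3 values shown sit.

Compound 4 `CCOS(=O)(=O)/C=C/c1ccc(OCC2=CC[C@@H]3C(C(=O)Nc4ccc(Oc5ccc(Br)cc5Cl)cc4)=CO[C@@H](OC)[C@H]23)cc1` is reached from compound 3 by one change, (4-bromo-2-chlorophenyl in place of 4-phenylphenyl on an oxygen on an aromatic ring). In words, 4-bromo-2-chlorophenyl stands in place of 4-phenylphenyl on an oxygen on an aromatic ring.

For the measured compounds named here, one measured step touches the same aryl group: a step that the two limits leave unreadable from compound 2 to compound 3. There, phenyl replaces hydrogen on an aromatic carbon, and since both ends are limits, the step gives neither a size nor a direction. Going by the values given here, the data hold no measured step with a halogen on this group, so the expectation for compound 4 rests on the shared limit in this assay. Compound 4 is expected to stay at that limit as well. The expected change is a number no higher from compound 3 to compound 4 (the limit leaves the size open), with no step beyond the scatter foreseen in either direction. For compound 4 the estimated value is 200000 nM. The expected range for compound 4 runs from 100000 nM to 300000 nM.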

Compound 4, half-maximal inhibitory concentration: > 200000 nM
Compound 4 was reported as a limit (the forecaster's own chance of this, stated with the estimate: 85%); the middle value lies on the limit itself.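

In this assay, for the compounds shown here, compound 4 is reported only as a limit, as are compound 2 and compound 3, so no step to compound 4 from either of them can be read. The compounds shown leave open whether any change on this aryl group alters cytotoxicity, and by how much.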